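Sulfonyl in place of carbonyl: what compound 4 might give

The source may hold more compounds than are shown below. What is called first, only, known or untested is meant among the compounds shown, and "the series" means these compounds.

Compound 1 `Cc1ccccc1C(=O)Nc1cccc(/C=C/C(=O)c2nc3ccccc3[nH]2)c1` sits second highest of the three numbers in a functional assay on HCT-116 cells (Homo sapiens) for antiproliferative activity, read by MTT assay, with a stated time of 48 h (a lower number here means a stronger inhibitor, a higher number a weaker inhibitor), where compound 1 gives 1870 nM. Compound 2 `O=C(Nc1cccc(/C=C/C(=O)c2nc3ccccc3[nH]2)c1)c1cccc(C(F)(F)F)c1` gives 3360 nM in this assay, and the shift a 1.8-fold higher number from compound 1 to compound 2 (0.25 log units; within the scatter) is one of the two measured steps. Compound 3 `O=C(/C=C/c1cccc(NS(=O)(=O)c2ccccc2Cl)c1)c1nc2ccccc2[nH]1` gives 987 nM in this assay, and a 1.9-fold lower number from compound 1 to compound 3 (0.28 log units; within the scatter) is the other. Compound 4 `Cc1ccccc1S(=O)(=O)Nc1cccc(/C=C/C(=O)c2nc3ccccc3[nH]2)c1` has not yet been measured; it differs from compound 1 in this way: (2-methylphenyl)sulfonyl in place of (2-methylphenyl)carbonyl on a nitrogen on an aromatic ring.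

Among the compounds with values here, the step that bears on this change is the one from compound 1 to compound 3, which also exchanges a carbonyl for a sulfonyl on the same nitrogen while the ring bears a chloro rather than a methyl; it stayed within the scatter. The step from compound 1 to compound 2 changes only the ring and is less informative. Compound 4 is therefore expected to land close to compound 1, with at most a small lowering, and the expected step is a 1.4-fold lower number from compound 1 to compound 4 (0.16 log units; within the scatter). The estimate for compound 4 in this assay is 1300 nM, expected to fall between 500 nM and 3000 nM.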

Compound 4, half-maximal inhibitory concentration: 955 nM
Estimate against measurement, compound 4: 1.4-fold (0.13 log units) above; the measured number falls inside the stated range.
By their numbers in this assay, from the lowest: compounds 4, 3, 1 and 2 (each within the scatter of the next, the first and the last beyond it).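

In this assay, the exchange of (2-methylphenyl)carbonyl for (2-methylphenyl)sulfonyl on the nitrogen now stands alone, with the ring substituent unchanged, and it gives a step that stays within the scatter (a 2.0-fold lower number from compound 1 to compound 4 (0.29 log units; within the scatter)), whereas the earlier step to compound 3 had also altered that substituent. Among the sulfonyl compounds, methyl in place of chloro on an aromatic carbon gives a step that is also within the scatter (a 1.0-fold lower number from compound 3 to compound 4 (0.01 log units; within the scatter)), so these two groups cannot be told apart here. No measurement at hand bears on the reason for these results.

The compounds shown leave open whether the sulfonyl group can carry a plain methyl or a longer alkyl chain instead of a substituted phenyl ring. They also leave open whether an amine or a carboxylic acid on that ring would shift the number beyond the scatter.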